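The source may hold more compounds than are shown below. What is called first, only, known or untested is meant among the compounds shown, and "the series" means these compounds.

Measured so far:
Compound 1 `COc1ccccc1-c1c(C(=O)c2cc(OC)c(OC)c(OC)c2)sc2ccccc12`: 3400 nM
Compound 2 `COc1ccc(-c2c(C(=O)c3cc(OC)c(OC)c(OC)c3)sc3ccccc23)cc1C`: > 10000 nM, a limit of the assay
Compound 3 `COc1cc(C(=O)c2sc3ccccc3c2Nc2ccccc2)cc(OC)c1OC`: 2300 nM

In a functional assay on K562 cells (Homo sapiens) for antiproliferative activity, read by MTT assay, with a stated time of 72 h (on this read-out higher numbers stand for weaker inhibition and lower numbers for stronger inhibition), compound 3 gives 2300 nM, which lies within the scatter of compound 1: a 1.5-fold lower number from compound 1 to compound 3 (0.17 log units; within the scatter). Compared with compound 2, known only as a limit, the gap is real: an at least 4.3-fold lower number from compound 2 to compound 3 (0.63 log units; beyond the scatter).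

Compound 4 `COc1cc(C(=O)c2sc3ccccc3c2Nc2ccc(Cl)cc2)cc(OC)c1OC` carries chloro in place of hydrogen on an aromatic carbon, para to a large group (chloro in place of hydrogen on an aromatic carbon). Among the measured compounds shown here, no measured step adds a chloro, so the guidance is indirect. The nearest hint comes from compound 2, where an at least 2.9-fold higher number from compound 1 to compound 2 (0.46 log units; beyond the scatter) shows that a different group at that place can raise the number. A small rise is therefore expected, perhaps none beyond the scatter. The expected change is a 1.5-fold higher number from compound 3 to compound 4 (0.18 log units; within the scatter). Compound 4 is estimated at 3500 nM, with an expected range of 1200 nM to 10000 nM.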

Compound 4, half-maximal inhibitory concentration: 1100 nM
The estimate for compound 4 lay 3.2-fold (0.50 log units) above the measured number; the whole stated range lies above it.
By their numbers in this assay, from the lowest: compound 4; then compounds 3 and 1 (each within the scatter of the next). At a limit, above all of these: compound 2.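

Chloro in place of hydrogen on the anilino ring gives a 2.1-fold lower number from compound 3 to compound 4 (0.32 log units; beyond the scatter) and so is a modest gain. Anilino and 2-methoxyphenyl sat within the scatter of each other, but the (4-chlorophenyl)amino group now separates from 2-methoxyphenyl, with a 3.1-fold lower number from compound 1 to compound 4 (0.49 log units; beyond the scatter) in this comparison. The step of an at least 9.0-fold lower number from compound 2 to compound 4 (0.95 log units; beyond the scatter) rests on a limit: the limit of > 10000 nM in this assay, at which 1 of the 4 values shown sits.

As far as these compounds go, whether bromo or methyl at this place would act like chloro stays open. So does the effect of an amine or a carboxylic acid on that carbon.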